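The compounds below may be only part of what the source reports. "The series", "measured", "known", "first", "only" and "open" are said of these compounds alone.

Compound 2 `Cc1ccc(S(=O)(=O)N(CC(=O)NCc2ccc(Cl)cc2)c2ccc(C)cn2)cc1` is known in an assay on CHO cells for displacement of a labelled ligand from prostaglandin E2 receptor EP1 subtype (Homo sapiens) (a lower number here means a stronger inhibitor, a higher number a weaker inhibitor), only through a limit, < 1000 nM. Compound 1 `Cc1ccc(S(=O)(=O)N(CC(=O)NCc2ccc(Cl)cc2)c2ccccn2)cc1` also stands at a limit in this assay, < 1000 nM. The step that the two limits leave unreadable from compound 1 to compound 2 cannot be read in size since (the limit of < 1000 nM in this assay, at which 2 of the 2 values shown sit). Compound 3 `CCn1nccc1N(CC(=O)NCc1ccc(Cl)cc1)S(=O)(=O)c1ccc(C)cc1` carries the change (1-ethyl-1H-pyrazol-5-yl in place of 5-methylpyridin-2-yl on a sulfonamide nitrogen). Among the compounds with values here, no measured step bears on this change, and the two limits give no scale for it, so its direction remains open. Compound 3 is expected to give 300 nM in this assay, within a range from 30 nM to 3000 nM. The expected step that the limit leaves unreadable from compound 2 to compound 3 is an estimate only.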

Compound 3, inhibition constant: 158 nM
Estimate against measurement, compound 3: 1.9-fold (0.28 log units) above; the range from low to high includes it.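

The steps from compound 1 and from compound 2 to compound 3 cannot be read in size, since compounds 1 and 2 are known only through a limit: the limit of < 1000 nM in this assay, at which 2 of the 3 values shown sit.

As far as these compounds go, whether 1-ethyl-1H-pyrazol-5-yl gives a stronger or weaker inhibitor than 5-methylpyridin-2-yl or pyridin-2-yl therefore stays open.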